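The compounds below may be only part of what the source reports. "The series", "measured", "known", "first", "only" and "open" are said of these compounds alone.

Measured compounds:
- compound 1, `CC(C)(C)CNC(=N)CS`: 95%
- compound 2, `O=C(CS)NC1CCCCC1`: 0%

In a functional assay on the whole organism (stomach, strain beagle) for inhibition, with Canis familiaris (Canis lupus familiaris) as the target, with a stated time of 2 h, at a dose of 8 mg/kg (on this read-out higher numbers stand for a stronger effect at the one dose given and lower numbers for a weaker effect), compound 1 gives 95%, the highest of the two numbers shown. Compound 2, built around an amide instead of an amidine, gives 0% in this assay, a gap beyond the usual scatter of repeated measurements. Only these two values are known, and since the two structures differ in more than one place, nothing can be said about which part of the change is responsible.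

Compound 3, `CC(C)(C)CNC(=N)CCCS`, has not yet been measured. It differs from compound 1 in one place: 2-sulfanylethyl in place of sulfanyl on a saturated chain carbon bound to a carbon with a double bond to nitrogen. The core of compound 1 and the amidine are kept, and only the chain that carries the sulfur is longer.

For the measured compounds named here, no step of this kind is known here, so the expectation rests on compound 1 alone. Because compound 1 gives 95%, a compound with the same core and amidine is estimated to keep part of that effect, but lengthening the chain is expected to cost something, with considerable uncertainty. Compound 3 is therefore estimated to give 55% in this assay, between 10% and 90%, which means an expected step of a number 40 percentage points lower from compound 1 to compound 3 (beyond the scatter) downward.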

Compound 3, a percentage reported as inhibition, in the whole organism at one dose (the size of the read-out at that dose, not a potency): 11%
Estimate against measurement, compound 3: 44 percentage points above; measured number inside the range.
By their numbers in this assay, from the lowest: compound 2; then compound 3; then compound 1.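

In this assay, putting 2-sulfanylethyl in place of sulfanyl on a saturated chain carbon bound to a carbon with a double bond to nitrogen gives a number 84 percentage points lower from compound 1 to compound 3 (beyond the scatter), a large loss from a change in one place. The amidine and the core of compound 1 are both kept in this pair, so these two parts alone do not secure the effect at this dose, and the length of the chain that carries the sulfur matters a great deal at this position. The data give no measurement that explains the size of this loss.

On these data alone, with only these two chain lengths, it remains open whether the effect fades gradually or drops abruptly as the chain grows, and sulfanylmethyl in place of sulfanyl on the same carbon would be the intermediate case. As far as these compounds go, it is also open whether the sulfur itself is needed at this position, a question that a hydroxyl group or an amine in place of sulfanyl could address.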